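The source may hold more compounds than are shown below. What is called first, only, known or untested is meant among the compounds shown, and "the series" means these compounds.

Among the compounds with values here, in a functional assay on A549 cells (Homo sapiens) for inhibition, read by sulforhodamine B assay, with a stated time of 72 h (on this read-out higher numbers stand for weaker inhibition and lower numbers for stronger inhibition), compound 1 (`Nc1sc(-c2ccc(Cl)cc2)c(-c2ccc(Cl)cc2)c1C(=O)N1CCCCC1=O`) gives 1820 nM as the higher of the two numbers measured so far, and compound 2 (`Nc1sc(-c2ccc(Cl)cc2)c(-c2ccc(Cl)cc2)c1C(=O)NC1CCC(O)CC1`) gives 250 nM on the same read-out. Compound 3 (`Nc1sc(-c2ccc(Cl)cc2)c(-c2ccc(Cl)cc2)c1C(=O)N1CCOCC1`) keeps the core of compound 1 and changes one group on a carbonyl carbon. The change is morpholin-4-yl in place of 2-oxopiperidin-1-yl on a carbonyl carbon and both groups are six-membered non-aromatic rings. Within the data shown here, only one measured step touches this place, a 7.3-fold lower number from compound 1 to compound 2 (0.86 log units; beyond the scatter) and it brought in a different group, so it shows that the number can move here but says little about morpholin-4-yl. In this assay a smaller step than that one is therefore expected, leaning toward a lower number and possibly not beyond the scatter. Compound 3 is estimated at 1100 nM within a range of 350 nM to 3200 nM for now. This estimate means an expected 1.7-fold lower number from compound 1 to compound 3 (0.22 log units; within the scatter) overall.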

Compound 3, half-maximal inhibitory concentration: 1870 nM
Compound 3: the middle estimate sits 1.7-fold (0.23 log units) below what was measured, and the stated range covers the measured number.
By their numbers in this assay, from the lowest: compound 2; then compounds 1 and 3 (each within the scatter of the next).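

In this assay, morpholin-4-yl in place of 2-oxopiperidin-1-yl gives a 1.0-fold higher number from compound 1 to compound 3 (0.01 log units; within the scatter), so these two six-membered non-aromatic rings on the carbonyl carbon cannot be told apart on this read-out. The step to the third group is much larger, a 7.5-fold higher number from compound 2 to compound 3 (0.87 log units; beyond the scatter), so among these three compounds the clear shift at this position goes with (4-hydroxycyclohexyl)amino alone, not with the exchange of one ring for the other. No supporting measurement is available to explain either step.

Still open, as far as these compounds go, is which part of (4-hydroxycyclohexyl)amino goes with the lower number: the hydroxyl, the amide hydrogen or the cyclohexyl ring. A plain cyclohexylamino group on the same carbonyl carbon would help to separate the hydroxyl from the rest.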